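Estimating permeability after a swap on the urea

The source may report more compounds than this note shows. Statements on the series, on what has been measured and on what is new or still open speak of the compounds shown alone.

Compound 1 `Cc1cc(NC(=O)Nc2ccc(C)c(Cl)c2)c2ccccc2n1`: 262 10^-6 cm/s
Compound 2 `Cc1cc(NC(=O)Nc2ccccc2N)c2ccccc2n1`: 300 10^-6 cm/s

These two numbers come from an ADME assay for permeability, using PAMPA, at pH 7.4; a lower number here means that the compound crosses the layer more slowly, a higher number that the compound crosses the layer faster. Compound 2 stands level with compound 1, since the gap between them lies within the usual scatter of repeated measurements and neither can be ranked above the other.

Compound 3 `Cc1ccc(NC(=O)Nc2cc(C)nc3ccccc23)cc1` has not been measured yet. It carries 4-methylphenyl in place of 2-aminophenyl on an amide-type nitrogen. Among the measured compounds shown here, no measured pair of compounds shows this change on its own, so the data give no direct guide to its size. For the measured compounds named here, the only anchors are compound 1 at 262 10^-6 cm/s and compound 2 at 300 10^-6 cm/s. A step beyond the scatter is therefore not expected, and no direction is favoured. The expected step of a 1.1-fold lower number from compound 2 to compound 3 (0.05 log units; within the scatter) is small. In this assay compound 3 is estimated at 270 10^-6 cm/s, with an expected range from 140 10^-6 cm/s to 480 10^-6 cm/s.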

Compound 3, apparent permeability: 669 10^-6 cm/s
Compound 3: middle estimate off by 2.5-fold (0.39 log units), on the low side, outside the stated range (above it).
By their numbers in this assay, from the lowest: compounds 1 and 2 (each within the scatter of the next); then compound 3.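

Swapping 2-aminophenyl for 4-methylphenyl on the amide-type nitrogen gives a 2.2-fold higher number from compound 2 to compound 3 (0.35 log units; beyond the scatter) in this assay, which shows that this position can respond to a change of aryl group, even though the two rings have the same number of heavy atoms. A smaller edit on the ring, hydrogen in place of chloro on an aromatic carbon, gives a 2.6-fold higher number from compound 1 to compound 3 (0.41 log units; beyond the scatter), so one substituent on this ring is enough to move the number beyond the scatter. Nothing measured here accounts for either step.

On these data alone, the first swap removes the amino group and adds the methyl at once, so the share of each in the step stays open. Also open, as far as these compounds go, is where a plain phenyl, a methoxy-bearing phenyl or a carboxylic acid on this ring would fall.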